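Changing the Halogenated Ring: What to Expect for Compound 4

The source may hold more compounds than are shown below. What is called first, only, known or untested is meant among the compounds shown, and "the series" means these compounds.

Measured so far in an ADME assay on MDBK cells (Bos taurus) for cytotoxicity, read by MTT assay, with a stated time of 96 h; on this read-out higher numbers stand for lower toxicity in this test and lower numbers for higher toxicity in this test:
Compound 1 `FC(F)(F)c1cccc(NC(=S)Nc2ccc(Cl)cc2)c1` gives 17000 nM.
Compound 2 `CCCC[C@H]1CC[C@H](c2ccc(NC(=S)Nc3cccc(C(F)(F)F)c3)cc2)CC1` gives 10000 nM.
Compound 3 `CCOC(=O)c1ccc(NC(=S)Nc2cccc(C(F)(F)F)c2)cc1` gives 64000 nM.

Compound 1 holds the second highest of the three numbers; its nearest neighbour is compound 2, with a 1.7-fold lower number from compound 1 to compound 2 (0.23 log units; within the scatter), and its furthest is compound 3, with a 3.8-fold higher number from compound 1 to compound 3 (0.58 log units; beyond the scatter). Compound 4 `FC(F)(F)c1cccc(NC(=S)Nc2ccccc2Br)c1` arises from compound 1 by the change (2-bromophenyl in place of 4-chlorophenyl on an amide-type nitrogen). Among the compounds with values here, none of the measured steps bears directly on this change: they, including a 6.4-fold higher number from compound 2 to compound 3 (0.81 log units; beyond the scatter), alter only the group on an aromatic carbon while keeping the ring, whereas here the whole 4-chlorophenyl leaves and 2-bromophenyl enters. Within the data shown here, with no guiding step, no shift beyond the scatter is expected, so compound 4 is expected to give 17000 nM (range 7000 nM to 45000 nM), amounting to an expected no change at the digits printed from compound 1 to compound 4 (within the scatter).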

Compound 4, half-maximal cytotoxic concentration: > 100000 nM
Compound 4: a limit, no number (the forecaster's own chance of this, stated with the estimate: 5%); middle value at least 5.8-fold (0.76 log units) from the limit.
By their numbers in this assay, from the lowest: compounds 2 and 1 (each within the scatter of the next); then compound 3. At a limit, above all of these: compound 4.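

In this assay, the group on the amide-type nitrogen turns out to matter: 2-bromophenyl in place of 4-chlorophenyl gives an at least 5.8-fold higher number from compound 1 to compound 4 (0.76 log units; beyond the scatter). Within the data shown here, this is a shift towards lower toxicity in this test, seen at a part of the molecule that the earlier steps left untouched. The result for compound 4 is a limit and not a number: the limit of > 100000 nM in this assay, at which 1 of the 4 values shown sits.

This swap alters the halogen and where it sits together, and the compounds shown do not separate the two. They also leave open how an amine or a carboxylic acid on that ring would read.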